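Series notes: chloro to dimethylamino

The source may report more compounds than this note shows. Statements on the series, on what has been measured and on what is new or still open speak of the compounds shown alone.

In a functional assay on A549 cells (Homo sapiens) for antiproliferative activity, read by MTT assay, with a stated time of 48 h (on this read-out lower numbers stand for stronger inhibition and higher numbers for weaker inhibition), compound 3 (`Cc1cc(Br)c2nc(-c3nnc(-c4ccc(Cl)cc4)o3)cn2c1`) gives 43500 nM, the highest of the three numbers, against compound 2 (`Cc1cc(Br)c2nc(-c3nnc(-c4ccccc4)o3)cn2c1`) at 14500 nM and compound 1 (`COc1cc(-c2nnc(-c3cn4cccc(C)c4n3)o2)cc(OC)c1OC`) at 9900 nM. Compound 4 (`Cc1cc(Br)c2nc(-c3nnc(-c4ccc(N(C)C)cc4)o3)cn2c1`) has dimethylamino in place of chloro on an aromatic carbon, para to a large group (dimethylamino in place of chloro on an aromatic carbon). For the measured compounds named here, no measured compound carries dimethylamino, so only one step bears on this change: a 3.0-fold higher number from compound 2 to compound 3 (0.48 log units; beyond the scatter), modest and beyond the scatter, for chloro in place of hydrogen. With chloro gone, that step suggests a modest move to a lower number in this assay, though not a certain one. The expected step is a 2.0-fold lower number from compound 3 to compound 4 (0.30 log units; within the scatter). For compound 4 the estimated value is 22000 nM, with an expected range of 8000 nM to 60000 nM.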

Compound 4, half-maximal inhibitory concentration: 10800 nM
Beside the measured number, compound 4's estimate is 2.0-fold (0.31 log units) above it; measured number inside the range.
By their numbers in this assay, from the lowest: compounds 1, 4 and 2 (each within the scatter of the next); then compound 3.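

On an aromatic carbon para to a large group, dimethylamino in place of chloro gives a 4.0-fold lower number from compound 3 to compound 4 (0.61 log units; beyond the scatter) in this assay and so removes the rise seen with chloro. Dimethylamino in place of hydrogen gives a 1.3-fold lower number from compound 2 to compound 4 (0.13 log units; within the scatter), so among these three groups only chloro stands apart at this place. No measured evidence on the cause of either step is available.

Open, as far as these compounds go, is whether a methoxy group or a primary amine here would stay with hydrogen and dimethylamino or move with chloro. Also open, from the compounds shown here alone, is whether a bromo group here would follow chloro.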